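From a Saturated Ring to an Aromatic One

The source may hold more compounds than are shown below. What is called first, only, known or untested is meant among the compounds shown, and "the series" means these compounds.

Three compounds have been measured in an assay on isolated protein for inhibition of Rho-associated protein kinase 1 (Homo sapiens), read by scintillation counting, radiometric assay and 33P incorporation, with a stated time of 40 min, in the presence of a further agent that is not named here; a higher number here means a weaker inhibitor, a lower number a stronger inhibitor:

compound 1, `COc1ccc(OCC(=O)Nc2cccc(NC(=O)c3ccc(N(C)C)cc3)c2)cc1OC`, gives only the limit > 10000 nM.
compound 2, `CN(C)c1ccc(C(=O)Nc2cccc(NC(=O)COc3ccc4c(c3)OCCO4)c2)cc1`, gives only the limit > 10000 nM.
compound 3, `CN(C)c1ccc(C(=O)Nc2cccc(NC(=O)COc3ccc4c(c3)OCCC4=O)c2)cc1`, gives 144 nM.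

Compound 3 thus stands as the only real number shown; the other two sit at the limit of > 10000 nM in this assay, at which 2 of the 3 values shown sit. The steps of an at least 69-fold lower number from compound 1 to compound 3 (1.84 log units; beyond the scatter) and an at least 69-fold lower number from compound 2 to compound 3 (1.84 log units; beyond the scatter) are large, whereas a step that the two limits leave unreadable from compound 1 to compound 2. Both large steps show that the group on the oxygen on the saturated carbon governs the result strongly.

Compound 4, `CN(C)c1ccc(C(=O)Nc2cccc(NC(=O)COc3ccc4occc(=O)c4c3)c2)cc1`, differs from compound 3 by a group of 11 heavy atoms (9 carbon, 2 oxygen; one six-membered aromatic ring of carbon only, one six-membered aromatic ring with 1 hetero atom) in place of a group of 11 heavy atoms (9 carbon, 2 oxygen; one six-membered non-aromatic ring with 1 hetero atom, one six-membered aromatic ring of carbon only), on an oxygen on a saturated carbon. The carbonyl and both acceptors are kept; the non-aromatic ring becomes aromatic. For the measured compounds named here, no measured step changes this part in this way, so the two large steps only say that this region matters, not in which direction this change moves. A modest step within the scatter is expected. The estimate means a 1.3-fold lower number from compound 3 to compound 4 (0.12 log units; within the scatter). Compound 4 is therefore expected to give about 110 nM, within 30 nM to 450 nM.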

Compound 4, half-maximal inhibitory concentration: > 10000 nM
Compound 4 gave a limit, no number; the forecaster's own chance of this, stated with the estimate: 10%; at least 90-fold (1.95 log units) between middle value and limit.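

For the compounds shown here, the earlier steps showed only that the group on the oxygen on the saturated carbon matters, while this one shows that making the non-aromatic ring aromatic is itself enough to matter: the change gives an at least 69-fold higher number from compound 3 to compound 4 (1.84 log units; beyond the scatter), a large step. It does so even though the heavy atoms, the double bond outside aromatic rings and the hydrogen-bond acceptors are counted the same on both sides, so those counts alone do not tell these two groups apart. In this assay compound 3 remains the only compound with a real number, and the steps among the other three cannot be read, since each of those compounds gives only a limit: the limit of > 10000 nM in this assay, at which 3 of the 4 values shown sit.

On these data alone, what stays open is which feature of the group in compound 3 is needed. The compounds shown do not tell whether a hydroxyl group in place of the carbonyl, or an amine nitrogen in place of the ring oxygen, would still give a measurable number.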